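Swapping the chain-end amine for a hydroxyethyl piperazine

The source may report more compounds than this note shows. Statements on the series, on what has been measured and on what is new or still open speak of the compounds shown alone.

In an assay on isolated protein (Cavia porcellus) with Sigma non-opioid intracellular receptor 1 (Homo sapiens) as the target, read by radioligand binding (on this read-out higher numbers stand for weaker inhibition and lower numbers for stronger inhibition), compound 2 `CN(CCCCCCOc1ccc2oc(-c3ccccc3)cc(=O)c2c1)Cc1ccccc1` gives 52 nM, and compound 1 `O=c1cc(-c2ccccc2)oc2ccc(OCCCCCCN3CCC(O)CC3)cc12` gives 100 nM, the two lying within the scatter of each other. Compound 3 `O=c1cc(-c2ccccc2)oc2ccc(OCCCCCCN3CCNC(CCO)C3)cc12` differs from compound 2 by 3-(2-hydroxyethyl)piperazin-1-yl in place of benzyl(methyl)amino on a saturated chain carbon, six bonds along the chain from an oxygen on an aromatic ring. Among the measured compounds shown here, the one measured step at this place, a 1.9-fold lower number from compound 1 to compound 2 (0.28 log units; within the scatter), exchanged one amine for another and stayed within the scatter, and compound 1 carries a 4-hydroxypiperidin-1-yl group there. The step of a 2.9-fold higher number from compound 2 to compound 3 (0.46 log units; beyond the scatter) is therefore expected to be small, if anything toward a higher number. For compound 3 the estimate is 150 nM, with a range from 40 nM to 600 nM.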

Compound 3, half-maximal inhibitory concentration: 63 nM
Compound 3: the middle estimate sits 2.4-fold (0.38 log units) above what was measured; measured number inside the range.
By their numbers in this assay, from the lowest: compounds 2, 3 and 1 (each within the scatter of the next).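

In this assay, this place on the chain takes a third amine with no shift beyond the scatter: the readings are a 1.2-fold higher number from compound 2 to compound 3 (0.08 log units; within the scatter) and a 1.6-fold lower number from compound 1 to compound 3 (0.20 log units; within the scatter). Here a non-aromatic ring with 2 hetero atoms replaces the aromatic ring of benzyl(methyl)amino, so that aromatic ring is not needed to stay in this range. No evidence is available to explain why these amines read alike. Still open, going by these compounds, is whether a carboxylic acid in place of the amine, or a longer chain, would keep the numbers in this range.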